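The source may hold more compounds than are shown below. What is called first, only, known or untested is meant among the compounds shown, and "the series" means these compounds.

For the measured compounds named here, in a functional assay on MIA PaCa-2 cells (Homo sapiens) for antiproliferative activity, read by sulforhodamine B assay, with a stated time of 48 h (a higher number here means a weaker inhibitor, a lower number a stronger inhibitor), compound 1 (`COc1cc(C(=O)/C=C\Nc2ccc(-c3nc4cc(OC)c(OC)c(OC)c4s3)cc2C)cc([N+](=O)[O-])c1OC`) gives 22000 nM, the higher of the two numbers measured so far, while compound 2 (`COc1ccc2nc(-c3ccc(N/C=C\C(=O)c4cc(OC)c(OC)c(OC)c4)c(C)c3)sc2c1`) gives 10000 nM. Compound 3 (`COc1ccc(C(=O)/C=C\Nc2ccc(-c3nc4cc(OC)c(OC)c(OC)c4s3)cc2C)cc1[N+](=O)[O-]`) departs from compound 1 by a single change: hydrogen in place of methoxy on an aromatic carbon. Going by the values given here, no measured pair isolates this change, so only a modest step towards a lower number, or none beyond the scatter, is expected in this assay. The estimated step is a 1.7-fold lower number from compound 1 to compound 3 (0.23 log units; within the scatter). For compound 3 the expected value is 13000 nM, with an estimated range of 4000 nM to 40000 nM.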

Compound 3, half-maximal inhibitory concentration: 23400 nM
Compound 3: middle estimate off by 1.8-fold (0.26 log units), on the low side, and the stated range covers the measured number.
By their numbers in this assay, from the lowest: compound 2; then compounds 1 and 3 (each within the scatter of the next).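

In this assay, for the compounds shown here, hydrogen in place of methoxy gives a 1.1-fold higher number from compound 1 to compound 3 (0.03 log units; within the scatter), the first reading of this change. At this place on the ring, ortho to a methoxy group and meta to a nitro group, removing the methoxy therefore produces no shift beyond the scatter. Nothing measured here offers an explanation for this result. The compounds shown leave open whether a hydroxyl, an amine or a longer alkoxy chain at this place would move the number beyond the scatter. They also leave open whether the same change would behave alike on a different core.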